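Fluorines in place of methoxy groups on the ketone ring

This account rests on a few compounds, and the source may have more. Where it says the series, first, only, none or still open, it means among the compounds named here.

Compound 2 `COc1ccc(C(=O)/C=C/c2cc(-c3cc(OC)c(OC)c(OC)c3)n[nH]2)cc1OC` stands lowest of the two numbers in a functional assay on IGROV-1 cells (Homo sapiens) for cytotoxicity, read by sulforhodamine B assay, with a stated time of 48 h, tested at 0.1 uM (a lower number here means a stronger effect, a higher number a weaker effect of the compound at the concentration tested), where compound 2 gives 96%. Among the compounds with values here, its only neighbour, compound 1 `COc1cc(-c2cc(/C=C/C(=O)c3ccc(N)cc3)[nH]n2)cc(OC)c1OC`, gives 108% in this assay, and the step of a number 12 percentage points lower from compound 1 to compound 2 (beyond the scatter) is the single change seen so far at this place. Compound 3 `COc1cc(-c2cc(/C=C/C(=O)c3ccc(F)c(F)c3)[nH]n2)cc(OC)c1OC` differs from compound 2 by 3,4-difluorophenyl in place of 3,4-dimethoxyphenyl on a carbonyl carbon. Within the data shown here, that earlier step, which exchanged a different ring at the same carbonyl carbon, was modest, and no measured step involves the 3,4-difluorophenyl ring, so the data give little guidance beyond showing that both measured numbers sit close together near full activity. The step of a number 4 percentage points higher from compound 2 to compound 3 (within the scatter) is therefore expected to be small, most likely within the scatter. Compound 3 is estimated at 100%, with a range from 82% to 116%.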

Compound 3, a percentage reported as activity, at one concentration (the size of the read-out at that concentration, not a potency): 97%
Estimate against measurement, compound 3: 3 percentage points above; low and high end bracket the measured number.
By their numbers in this assay, from the lowest: compounds 2 and 3 (each within the scatter of the next); then compound 1.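

Exchanging the ring on the carbonyl carbon gives a number 1 percentage points higher from compound 2 to compound 3 (within the scatter) in this assay, so 3,4-difluorophenyl and 3,4-dimethoxyphenyl cannot be told apart here, even though the leaving ring carries hydrogen-bond acceptors and the entering ring carries none. Compound 1, with its 4-aminophenyl ring, now stands apart from both other compounds: the step to the difluorophenyl ring, a number 11 percentage points lower from compound 1 to compound 3 (beyond the scatter), is modest and runs in the same direction as the earlier a number 12 percentage points lower from compound 1 to compound 2 (beyond the scatter). No measurement available here accounts for this picture.

On these data alone, it remains open whether any ring at this carbonyl carbon would lower the number much further in this assay, for example a phenyl ring bearing a carboxylic acid, or a pyridine ring. A single fluorine on the ring would also show whether the two fluorines of compound 3 behave as a pair.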